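The source may report more compounds than this note shows. Statements on the series, on what has been measured and on what is new or still open speak of the compounds shown alone.

Three compounds of one family share a core that carries a hydroxyphenyl group, a chlorophenyl group and a third aromatic ring. Compound 1 `Oc1ccc(-c2cc(-c3cccnc3)nc(-c3ccccc3Cl)c2)cc1` bears a pyridin-3-yl group as that third ring, compound 2 `Oc1cccc(-c2cc(-c3ccc(Cl)cc3)nc(-c3ccco3)c2)c1` a furan ring, and compound 3 `Oc1cccc(-c2cc(-c3cccnc3)nc(-c3cccc(Cl)c3)c2)c1` again a pyridin-3-yl group. In a functional assay on DU-145 cells (Homo sapiens) for cytotoxicity, read by CCK-8 assay and cell counting, with a stated time of 2 days (on this read-out lower numbers stand for stronger inhibition and higher numbers for weaker inhibition), compound 2 gives 11400 nM. For compound 1 the entry in this assay reads "not determined" (no result reported), so no number stands behind it, and for compound 3 the entry in this assay likewise reads "not determined" (no result reported). Compound 1 therefore has no place on a numerical scale yet, and one further compound of the set is in the same position.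

Compound 4 `Oc1ccc(-c2cc(-c3ccsc3)nc(-c3ccccc3Cl)c2)cc1` differs from compound 1 in one spot: thiophen-3-yl in place of pyridin-3-yl on an aromatic carbon. Only compound 2 offers a measured anchor for this family, so any expectation for compound 4 is loose. In this assay the step from compound 1 to compound 4 is expected to stay within the usual scatter, with no clear direction. Compound 4 is estimated at 10000 nM, within a range from 2000 nM to 50000 nM.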

Compound 4, half-maximal inhibitory concentration: 3890 nM
Compound 4: the middle estimate sits 2.6-fold (0.41 log units) above what was measured; low and high end bracket the measured number.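

The change from compound 1 to compound 4 cannot be read as a step, since in this assay compound 1 has no number to compare. No supporting data speak to the value of compound 4. Going by these compounds, how thiophen-3-yl compares with pyridin-3-yl on this core stays open.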